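A few compounds are considered here, and "the series" means these few. Any claim that something is new, unique, unknown or untested is made for them only; others in the source may bear on it.

Measured so far in an assay on isolated protein for inhibition of DNA topoisomerase 1 (Homo sapiens), with a stated time of 30 min, tested at 100 uM; a lower number here means less inhibition, a higher number more inhibition at the concentration tested (going by the name of the read-out):
compound 1 `Cc1ccc(S(=O)(=O)n2c(-c3ccccc3)c(C#CCO[C@H]3CC[C@H](N)[C@H](C)O3)c3ccccc32)cc1`: 43.2%
compound 2 `C[C@@H]1O[C@@H](OCC#Cc2c(-c3ccccc3)[nH]c3ccccc23)C[C@H](N)[C@@H]1O`: 8.8%
compound 3 `C[C@@H]1O[C@@H](OCC#Cc2c(-c3ccccc3)[nH]c3ccccc23)C[C@H](N)[C@H]1O`: 8.2%

For the measured compounds named here, compound 3 gives the lowest of the three numbers; compound 2 stands within the scatter of it, while compound 1 stands well beyond it, though compound 1 and compound 3 differ in more than one place and no single step joins them. Going by the values given here, the only measured step that bears on the part of the molecule in question is a number 0.6 percentage points lower from compound 2 to compound 3 (within the scatter), a pair that differs only in configuration as drawn (the fact that compounds 2 and 3 differ only in the configuration as drawn), and the read-out did not move beyond the scatter. Compound 4 `C[C@@H]1O[C@@H](OCC#Cc2c(-c3ccccc3)[nH]c3ccccc23)CC[C@@H]1N` carries the change (a group of 8 heavy atoms (6 carbon, 1 nitrogen, 1 oxygen; one six-membered non-aromatic ring with 1 hetero atom) in place of a group of 9 heavy atoms (6 carbon, 1 nitrogen, 2 oxygen; one six-membered non-aromatic ring with 1 hetero atom), on an oxygen on a saturated carbon). Among the compounds with values here, with the one step at this position flat, a step of a number 0.8 percentage points higher from compound 3 to compound 4 (within the scatter) with no movement beyond the scatter is expected. Compound 4 is estimated at 9%, between 0% and 25%.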

Compound 4, a percentage reported as inhibition, at one concentration (the size of the read-out at that concentration, not a potency): 4%
Compound 4: middle estimate off by 5 percentage points, on the high side, within the range that was stated.
By their numbers in this assay, from the lowest: compounds 4, 3 and 2 (each within the scatter of the next); then compound 1.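

In this assay, 5-amino-6-methyloxan-2-yl on this oxygen gives a number 4.2 percentage points lower from compound 3 to compound 4 (within the scatter) and also a number 4.8 percentage points lower from compound 2 to compound 4 (within the scatter), so this change leaves the read-out flat against either configuration of the group it replaces. For the compounds shown here, compound 4 also supplies the first single-place comparison on the aromatic nitrogen: hydrogen in place of (4-methylphenyl)sulfonyl gives a number 39.2 percentage points lower from compound 1 to compound 4 (beyond the scatter) in this series.

Going by these compounds, what an acetyl or a methylsulfonyl on that nitrogen would give stays open. No evidence shown bears on the cause of these steps.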